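Swapping the phenyl substituent on the triazole: cytotoxicity outlook

A few compounds are considered here, and "the series" means these few. Any claim that something is new, unique, unknown or untested is made for them only; others in the source may bear on it.

Measured compounds so far:
- compound 1 `Cc1ccccc1-n1cc(-c2ccccc2NS(=O)(=O)c2c[nH]c(=O)[nH]c2=O)nn1`: 19900 nM
- compound 2 `Cc1ccc(-n2cc(-c3ccccc3NS(=O)(=O)c3c[nH]c(=O)[nH]c3=O)nn2)cc1`: 32400 nM
- compound 3 `O=c1[nH]cc(S(=O)(=O)Nc2ccccc2-c2cn(-c3ccccc3Cl)nn2)c(=O)[nH]1`: 20800 nM

In an ADME assay on GES1 cells (Homo sapiens) for cytotoxicity, read by MTT assay, with a stated time of 24 h (on this read-out higher numbers stand for lower toxicity in this test and lower numbers for higher toxicity in this test), compound 2 gives 32400 nM. The three numbers sit close together: a 1.6-fold higher number from compound 1 to compound 2 (0.21 log units; within the scatter) and a 1.6-fold lower number from compound 2 to compound 3 (0.19 log units; within the scatter), so compound 2 cannot be separated from compound 1 or compound 3 on this read-out.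

The step considered here leads from compound 2 to compound 4 `O=c1[nH]cc(S(=O)(=O)Nc2ccccc2-c2cn(-c3cccc(Cl)c3)nn2)c(=O)[nH]1`, which is not yet measured. The change is 3-chlorophenyl in place of 4-methylphenyl on an aromatic nitrogen, in words: 3-chlorophenyl in place of 4-methylphenyl on an aromatic nitrogen.

For the measured compounds named here, three measured steps bear on it. Moving the methyl group around the same ring, a 1.6-fold higher number from compound 1 to compound 2 (0.21 log units; within the scatter). Replacing a methyl with a chloro on the same ring carbon, a 1.0-fold higher number from compound 1 to compound 3 (0.02 log units; within the scatter). Exchanging the whole 4-methylphenyl for 2-chlorophenyl, a 1.6-fold lower number from compound 2 to compound 3 (0.19 log units; within the scatter). Each of these changes touched the same phenyl on the triazole nitrogen, and none moved the number beyond the scatter. The step to compound 4 combines a methyl-to-chloro exchange with a shift of position, both of which individually stayed flat.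

For compound 4 the expectation is therefore no change beyond the scatter, an estimated step of a 1.3-fold lower number from compound 2 to compound 4 (0.11 log units; within the scatter). Compound 4 is estimated at 25000 nM, with a range from 12000 nM to 50000 nM.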

Compound 4, half-maximal cytotoxic concentration: > 100000 nM
Compound 4: a limit, no number (the forecaster's own chance of this, stated with the estimate: 10%); at least 4.0-fold (0.60 log units) between middle value and limit.
By their numbers in this assay, from the lowest: compounds 1, 3 and 2 (each within the scatter of the next). At a limit, above all of these: compound 4.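

Compound 4 stands at a limit of this assay, not at a number: the limit of > 100000 nM in this assay, at which 1 of the 4 values shown sits.

Even with that limit, the steps can be read, and all three lie beyond the scatter: an at least 3.0-fold higher number from compound 2 to compound 4 (0.48 log units; beyond the scatter), an at least 4.8-fold higher number from compound 3 to compound 4 (0.68 log units; beyond the scatter) and an at least 5.0-fold higher number from compound 1 to compound 4 (0.70 log units; beyond the scatter). The earlier exchanges on this phenyl on the aromatic nitrogen all stayed within the scatter, so 3-chlorophenyl is the first group among these four compounds to separate from the others, and it does so in the direction of lower toxicity in this test. The step from compound 3 is the most telling, since both compounds carry a chloro on the phenyl and differ only in 2-chlorophenyl against 3-chlorophenyl, which shows that the mere presence of chloro does not account for the result.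

The four compounds leave open whether this belongs to chloro itself or to any group at that ring position, since 3-methylphenyl and 4-chlorophenyl are not among them. They also say nothing about how a 3-aminophenyl or a phenyl carrying a carboxylic acid would behave in this place.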